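A few compounds are considered here, and "the series" means these few. Any claim that something is new, unique, unknown or untested is made for them only; others in the source may bear on it.

Measured compounds:
compound 1 `CCOC(=O)N1CCC(Oc2cc(Oc3ccc(/C=C4\SC(=O)NC4=O)cc3)ncn2)CC1` — 790 nM
compound 2 `CC(C)(C)OC(=O)N1CCC(Oc2cc(Oc3ccc(/C=C4\SC(=O)NC4=O)cc3)ncn2)CC1` — 130 nM
compound 3 `CCOC(=O)N1CCC(Oc2cc(Oc3cccc(/C=C4\SC(=O)NC4=O)c3)ncn2)CC1` — 819 nM

All three were run in a functional assay on CHO-K1 cells for agonist activity at Glucose-dependent insulinotropic receptor (Homo sapiens), read by cAMP accumulation and immunoassay, with a stated time of 1 h; on this read-out higher numbers stand for an effect only at larger amounts of compound and lower numbers for an effect already at smaller amounts. Compound 1 and compound 2 share one core; compound 3 sits on a second core, and the difference between the two cores is not broken down here. In this assay compound 1 gives 790 nM and compound 3 gives 819 nM, two numbers that lie within the scatter of each other, so nothing separates them.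

Within the first core the change tert-butyl in place of ethyl on an oxygen next to a carbonyl group gave a 6.1-fold lower number from compound 1 to compound 2 (0.78 log units; beyond the scatter), with compound 2 at 130 nM.

Compound 4 `CC(C)(C)OC(=O)N1CCC(Oc2cc(Oc3cccc(/C=C4\SC(=O)NC4=O)c3)ncn2)CC1` is not yet measured. It differs from compound 3 by tert-butyl in place of ethyl on an oxygen next to a carbonyl group, the same change, made at the same place, as that from compound 1 to compound 2. Among the compounds with values here, only one earlier instance of this change exists, so the expectation rests on that single step. Within the data shown here, compound 4 is expected to show a 5.5-fold lower number from compound 3 to compound 4 (0.74 log units; beyond the scatter), because a 6.1-fold lower number from compound 1 to compound 2 (0.78 log units; beyond the scatter) is the sole precedent. Compound 4 is therefore estimated at 150 nM, with a likely range from 60 nM to 400 nM.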

Compound 4, half-maximal effective concentration: 125 nM
For compound 4 the middle estimate is 1.2-fold (0.08 log units) above the measured one; low and high end bracket the measured number.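

In this assay, tert-butyl in place of ethyl on an oxygen next to a carbonyl group gave a 6.6-fold lower number from compound 3 to compound 4 (0.82 log units; beyond the scatter), so the change carries over to the core of compound 3. Its size does not differ between the two cores: the same change on two cores in this assay, a 6.1-fold lower number (0.78 log units; beyond the scatter) from compound 1 to compound 2 and a 6.6-fold lower number (0.82 log units; beyond the scatter) from compound 3 to compound 4, 1.1-fold (0.03 log units) apart, within the scatter of two such steps. This shows that, for these two cores and this one assay, the step can be carried from one core to the other with no visible loss or gain, but it does not show that the step would hold on any further core or in any other assay, and it gives no reason for the lower number.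

The compounds shown leave open whether the step follows the branching of the chain or simply its size, a question that isopropyl and n-butyl at the same place on either core would address. They also leave open how far the step depends on the oxygen itself, which an amide or a urea in place of the carbamate would test.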